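Removing the aromatic methyl from compound 3

The source may hold more compounds than are shown below. What is called first, only, known or untested is meant among the compounds shown, and "the series" means these compounds.

In a functional assay on BaF3 cells (Mus musculus) for antiproliferative activity (a higher number here means that more compound is needed for the effect, a lower number that less compound is needed), compound 1 (`CCN1CCN(Cc2ccc(NC(=O)c3ccc(C)c(C#Cc4ccc(NC(=O)C5CC5)nc4)c3)cc2C(F)(F)F)CC1`) gives 1800 nM, compound 2 (`CCN1CCN(Cc2ccc(NC(=O)c3ccc(C)c(C#Cc4cnc(N)cn4)c3)cc2C(F)(F)F)CC1`) gives 860 nM and compound 3 (`CCN1CCN(Cc2ccc(NC(=O)c3ccc(C)c(C#Cc4cnc5[nH]ccc5c4)c3)cc2C(F)(F)F)CC1`) gives 1000 nM. Compound 3 stands within the scatter of both others, with a 1.8-fold lower number from compound 1 to compound 3 (0.26 log units; within the scatter) and a 1.2-fold higher number from compound 2 to compound 3 (0.07 log units; within the scatter). Compound 4 (`CCN1CCN(Cc2ccc(NC(=O)c3cccc(C#Cc4cnc5[nH]ccc5c4)c3)cc2C(F)(F)F)CC1`) differs from it by hydrogen in place of methyl on an aromatic carbon. For the measured compounds named here, the one step beyond the scatter, a 2.1-fold lower number from compound 1 to compound 2 (0.32 log units; beyond the scatter), is modest, and it changes the group on the triple-bonded carbon, as do the other two steps. Going by the values given here, no measured step touches the methyl, so the guidance is only indirect. In this assay, the expected result is a 1.1-fold higher number from compound 3 to compound 4 (0.04 log units; within the scatter), a change not beyond the scatter in either direction. The estimate for compound 4 is 1100 nM, with an expected range of 450 nM to 2700 nM.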

Compound 4, half-maximal effective concentration: > 10000 nM
Compound 4: only a limit was reported; the forecaster's own chance of this, stated with the estimate: 5%; middle value at least 9.0-fold (0.95 log units) from the limit.
By their numbers in this assay, from the lowest: compounds 2, 3 and 1 (each within the scatter of the next, the first and the last beyond it). At a limit, above all of these: compound 4.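

The methyl on the aromatic carbon, ortho to a large group and para to a large group, carries weight in this assay, as hydrogen in place of methyl gives an at least 10-fold higher number from compound 3 to compound 4 (1.00 log units; beyond the scatter). For the compounds shown here, no step among compound 1, compound 2 and compound 3, all changes on the triple-bonded carbon, showed a shift of this size. Compound 4 carries a limit, not a number: the limit of > 10000 nM in this assay, at which 1 of the 4 values shown sits.

As far as these compounds go, whether an ethyl group or a chlorine atom at this position would hold the activity of compound 3 stays open. So does whether removing the methyl from compound 2 would have a similar effect.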